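Removing the fluoro from the aryl group of compound 3

The source may hold more compounds than are shown below. What is called first, only, known or untested is meant among the compounds shown, and "the series" means these compounds.

The shared core of compound 1 `COc1cc2ccc(=O)oc2cc1OC(=O)c1c(C)noc1-c1ccccc1` carries an ester-linked five-membered ring bearing a phenyl group. In a functional assay on Huh-7 cells (Homo sapiens) for inhibition, read by MTT assay, with a stated time of 48 h (on this read-out lower numbers stand for stronger inhibition and higher numbers for weaker inhibition), compound 1 gives only a limit, > 25000 nM. Compound 2 `COc1cc2ccc(=O)oc2cc1OC(=O)c1c(-c2ccc(Cl)cc2)n[nH]c1C` carries a 4-chlorophenyl on its ester-linked ring, and in this assay compound 2 gives 16200 nM. Compound 3 `COc1cc2ccc(=O)oc2cc1OC(=O)c1c(-c2ccccc2F)n[nH]c1C` has 2-fluorophenyl in the same place. In this assay compound 3 gives only a limit, > 25000 nM. Compound 3 thus stands at the limit described by the limit of > 25000 nM in this assay, at which 2 of the 3 values shown sit, and the step of an at least 1.5-fold higher number from compound 2 to compound 3 (0.18 log units; that floor lies within the scatter) is only a floor that does not pass the scatter.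

Compound 4 `COc1cc2ccc(=O)oc2cc1OC(=O)c1c(-c2ccccc2)n[nH]c1C` differs from compound 3 by hydrogen in place of fluoro on an aromatic carbon of a six-membered aromatic ring of carbon only. Among the compounds with values here, the only measured step touching this ring, an at least 1.5-fold higher number from compound 2 to compound 3 (0.18 log units; that floor lies within the scatter), is a floor within the scatter, so no direction can be read from it; compound 1, also at the limit, shows no measurable inhibition with a phenyl on its ester-linked ring either. No step beyond the scatter is therefore expected in this assay: a number no higher from compound 3 to compound 4 (the limit leaves the size open). For compound 4 the estimate in this assay is 25000 nM, ranging from 12000 nM to 60000 nM, and most likely a limit is reported again.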

Compound 4, half-maximal inhibitory concentration: > 25000 nM
Compound 4 ended at the assay's limit; the forecaster's own chance of this, stated with the estimate: 60%; the middle value sits exactly at the limit.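

With hydrogen in place of fluoro, compound 4 gives only a limit in this assay, as compound 3 does, so the step between these two cannot be read and the fluoro shows no effect in either direction. The comparison with compound 2 now has the plain phenyl as its reference, and it gives an at least 1.5-fold higher number from compound 2 to compound 4 (0.18 log units; that floor lies within the scatter), so hydrogen in place of chloro gives no step beyond the scatter, and the 4-chlorophenyl cannot be credited with a real gain over phenyl. The series now sits almost entirely at one end of the measurable range: the limit of > 25000 nM in this assay, at which 3 of the 4 values shown sit.

The compounds shown leave open whether any group on this aromatic ring can bring the number clearly below the limit in this assay, for example an amine, a carboxylic acid or a longer chain such as a butyl group in place of the chloro of compound 2. They also leave open how far apart compound 1, compound 3 and compound 4 really lie, since a limit gives no position for any of them.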